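Swapping phenyl for butyl on the triazole

This account rests on a few compounds, and the source may have more. Where it says the series, first, only, none or still open, it means among the compounds named here.

Of the compounds shown here, two in this set have been measured. Compound 1 `COc1nc2ccc(Br)cc2cc1C(c1ccccc1)n1cc(-c2ccc(Br)cc2)nn1` gives 10.4% in an ADME assay on PANC-1 cells (Homo sapiens) for cytotoxicity, read by sulforhodamine B assay, with a stated time of 48 h, tested at 10 uM; on this read-out lower numbers stand for less inhibition and higher numbers for more inhibition at the one concentration tested (going by the name of the read-out). Compound 2 `COc1nc2ccc(Br)cc2cc1C(c1ccccc1)n1cc(-c2ccccc2)nn1` gives 30.1% in this assay, the highest of the two numbers; its nearest neighbour is compound 1. For the measured compounds named here, the only step measured so far, a number 19.7 percentage points higher from compound 1 to compound 2 (beyond the scatter), came from hydrogen in place of bromo on an aromatic carbon. Compound 3 `CCCCc1cn(C(c2ccccc2)c2cc3cc(Br)ccc3nc2OC)nn1` is not yet measured; it differs from compound 2 by butyl in place of phenyl on an aromatic carbon. Going by the values given here, no measured step bears directly on this change: the one step known alters a substituent on the phenyl, whereas here the whole phenyl is replaced by a chain. With nothing to point in either direction, the expectation for a number 5.1 percentage points lower from compound 2 to compound 3 (within the scatter) is a step that stays within the scatter. Compound 3 is therefore estimated at 25% in this assay, with a range from 5% to 45%.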

Compound 3, a percentage reported as inhibition, at one concentration (the size of the read-out at that concentration, not a potency): 5.46%
Beside the measured number, compound 3's estimate is 19.5 percentage points above it; low and high end bracket the measured number.
By their numbers in this assay, from the lowest: compounds 3 and 1 (each within the scatter of the next); then compound 2.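

In this assay, butyl in place of phenyl gives a number 24.6 percentage points lower from compound 2 to compound 3 (beyond the scatter), so this position responds to replacing the whole ring with an open chain, and not only to a change on the phenyl. Butyl in place of 4-bromophenyl gives a number 4.9 percentage points lower from compound 1 to compound 3 (within the scatter), so a chain and a bromo-bearing ring cannot be told apart here, and compound 2 alone stands clear of the other two. No measurement shown offers a reason for either step.

As far as these compounds go, it remains open whether the ring as such matters here, or only this unsubstituted phenyl, since one chain and one substituted phenyl are a narrow sample. A cyclohexyl ring, a pyridine ring, a shorter or longer chain, or a chain ending in an amine could each help separate these possibilities.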